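The source may report more compounds than this note shows. Statements on the series, on what has been measured and on what is new or still open speak of the compounds shown alone.

Measured so far: compound 1 `CCCNC(=O)NCCCc1cccc2ccc(OC)cc12`, in an assay (Ovis aries) for binding affinity to melatonin receptor type 1A (Homo sapiens) (on this read-out lower numbers stand for stronger inhibition and higher numbers for weaker inhibition), compound 1 gives 251 nM; compound 2 `COc1ccc2cccc(CCCC(N)=O)c2c1`, in this assay compound 2 gives 20 nM.

Going by the values given here, compound 2 holds the lowest of the two numbers, the one step on record running a 13-fold lower number from compound 1 to compound 2 (1.10 log units; beyond the scatter). Compound 3 `CNC(=O)c1cccc2ccc(OC)cc12` differs from compound 2 by methylcarbamoyl in place of 3-carbamoylpropyl on an aromatic carbon. Among the compounds with values here, that measured step only swapped the group at the end of the chain and kept the chain; no step on record removes the chain itself, so it bears on this change only loosely. With the chain gone, compound 3 is expected to give a weaker result, estimated at 2000 nM, between 300 nM and 20000 nM, a step of a 100-fold higher number from compound 2 to compound 3 (2.00 log units; beyond the scatter).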

Compound 3, half-maximal inhibitory concentration: 1260 nM
Estimate against measurement, compound 3: 1.6-fold (0.20 log units) above, within the range that was stated.
By their numbers in this assay, from the lowest: compound 2; then compound 1; then compound 3.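

On this aromatic carbon, replacing 3-carbamoylpropyl with methylcarbamoyl costs far more than the earlier change at the chain's end, giving a much weaker result (a 63-fold higher number from compound 2 to compound 3 (1.80 log units; beyond the scatter)). Both groups count one hydrogen-bond donor and one hydrogen-bond acceptor, so those counts alone do not separate compound 2 from compound 3. No measurement here explains the loss.

Still open, going by these compounds, is whether a shorter chain would recover part of it, or whether a methyl on the amide nitrogen of compound 2 would matter. On these data alone, an amine or a carboxylic acid at the chain's end also remains untested here.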